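The compounds below may be only part of what the source reports. "The series", "measured", "known", "first", "only" and "open" are said of these compounds alone.

Measured compounds:
Compound 1 `C=CC[C@@H]1C[C@]2([C@H](C)Cc3ccc(OC)c(OC)c3)OCOC2=CC1=O`: in a functional assay on M14 cells (Homo sapiens) for antiproliferative activity, with a stated time of 72 h (on this read-out lower numbers stand for stronger inhibition and higher numbers for weaker inhibition), compound 1 gives the limit > 4000 nM.
Compound 2 `C=CC[C@H]1C[C@]2([C@@H](C)Cc3ccc(OC)c(C(=O)NC)c3)OCOC2=CC1=O`: in this assay compound 2 gives 1400 nM.

Compound 2 holds the only number shown in this assay. The value of compound 1 is a limit, and one of the two values sits at it (the limit of > 4000 nM in this assay, at which 1 of the 2 values shown sits). Compound 3 `C=CC[C@H]1C[C@]2([C@@H](C)Cc3ccc(OC)c(F)c3)OCOC2=CC1=O` is not yet measured in this assay. It differs from compound 2 in one place (fluoro in place of methylcarbamoyl on an aromatic carbon), fluoro in place of methylcarbamoyl on an aromatic carbon. Among the compounds with values here, no step between measured compounds is recorded here, so the size of such a change cannot be read from any measured pair. For compound 3 a step toward weaker inhibition is expected in this assay, with a real chance that only a limit is returned. The estimate for compound 3 is 3500 nM, between 1200 nM and 10000 nM. The expected step from compound 2 to compound 3 is a 2.5-fold higher number from compound 2 to compound 3 (0.40 log units; beyond the scatter).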

Compound 3, half-maximal inhibitory concentration: 8 nM
Compound 3: the middle estimate sits 440-fold (2.64 log units) above what was measured; measured number below the stated range.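

In this assay, within the data shown here, the change of methylcarbamoyl to fluoro gives a 180-fold lower number from compound 2 to compound 3 (2.24 log units; beyond the scatter), the first step that can be read from a measured pair. The aromatic carbon ortho to a methoxy group is therefore not a neutral place on this scaffold: exchanging a group of 4 heavy atoms, with 1 hydrogen-bond donor and 1 hydrogen-bond acceptor, for a single fluorine moves the read-out far beyond the usual scatter. Nothing shown gives a cause for a step of this size.

This single pair does not separate what is lost with the methylcarbamoyl from what is gained with the fluoro. As far as these compounds go, how hydrogen, chloro, a nitrile or an amine on the same carbon would read in this assay remains open.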